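A few compounds are considered here, and "the series" means these few. Any claim that something is new, unique, unknown or untested is made for them only; others in the source may bear on it.

For the measured compounds named here, compound 1 `Cc1cc(O)c(C(=O)/C=C/c2ccc(F)cc2)c(-c2ccc(OCc3ccccc3)cc2)c1C(=O)/C=C/c1ccc(F)cc1` is the one compound in this set that comes with a number: in a functional assay on MDA-MB-231 cells (Homo sapiens) for cytotoxicity, read by MTT assay, with a stated time of 24 h (on this read-out higher numbers stand for weaker inhibition and lower numbers for stronger inhibition), compound 1 gives 15000 nM. The two companions give no number at all. Compound 2 `COc1ccc(/C=C/C(=O)c2c(C)cc(O)c(C(=O)/C=C/c3ccc(OC)c(OC)c3)c2-c2ccccc2)cc1OC` is recorded in this assay as "not active" (no number reported), and compound 3 `Cc1cc(O)c(C(=O)/C=C/c2ccccc2)c(-c2ccc(OCc3ccccc3)cc2)c1C(=O)/C=C/c1ccccc1` is recorded in this assay as "not active" (no number reported). So compound 1 stands alone as the only entry with a measured value, and nothing can be said about how far it sits from the other two.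

The step of interest leads to compound 4 `Cc1cc(O)c(C(=O)/C=C/c2ccc(F)cc2)c(-c2ccccc2)c1C(=O)/C=C/c1ccc(F)cc1`. Between compound 1 and compound 4 the change is hydrogen in place of benzyloxy on an aromatic carbon. Going by the values given here, no pair of measured compounds shows this same change, so there is no measured step to lean on; compound 2 and compound 3, both without a number, differ from compound 1 in more than one place.

With compound 1 as the only anchor, the expectation is a modest loss of potency in this assay, a step from compound 1 to compound 4 of about a 2.0-fold higher number from compound 1 to compound 4 (0.30 log units; within the scatter), and a real chance that no number is reported. Compound 4 is thus estimated at 30000 nM, within a range from 10000 nM to 100000 nM.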

Compound 4, half-maximal inhibitory concentration: 20000 nM
For compound 4 the middle estimate is 1.5-fold (0.18 log units) above the measured one, and the stated range covers the measured number.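

With hydrogen in place of benzyloxy, on an aromatic carbon para to a large group, this assay shows a 1.3-fold higher number from compound 1 to compound 4 (0.12 log units; within the scatter), so the two compounds cannot be told apart on this read-out. For the compounds shown here, this is the first look at this position, and it shows that a measured number does not depend on the benzyloxy group: compound 4 lacks all 8 of its heavy atoms, including its six-membered aromatic ring and its hydrogen-bond acceptor, yet still gives a value, whereas the only earlier compound with a number carried that group. No measurement shown here explains why this exchange leaves the read-out within the scatter.

As far as these compounds go, with only hydrogen and benzyloxy compared at this position, it remains open whether a different kind of group, such as an amine or a carboxylic acid, would give a clearly different number in this assay or no number at all. From the compounds shown here alone, it is also open whether the same exchange would give a similarly small step in compounds with other groups on the two side chains, since this single pair carries a fluorine on each chain.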